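This account rests on a few compounds, and the source may have more. Where it says the series, first, only, none or still open, it means among the compounds named here.

Measured so far in an ADME assay on Vero cells (Chlorocebus sabaeus) for cytotoxicity, read by MTT assay, with a stated time of 72 h; on this read-out lower numbers stand for higher toxicity in this test and higher numbers for lower toxicity in this test:

compound 1 `CC(C)CN(CC(C)C)N1CCN(c2nc(=O)c3cc(C(F)(F)F)cc([N+](=O)[O-])c3s2)CC1` — > 64 ug/mL
compound 2 `CON=C1CCC(N(C)N2CCN(c3nc(=O)c4cc(C(F)(F)F)cc([N+](=O)[O-])c4s3)CC2)CC1` — > 64 ug/mL
compound 3 `O=c1nc(N2CCN(NCc3ccc(C(F)(F)F)cc3)CC2)sc2c([N+](=O)[O-])cc(C(F)(F)F)cc12` — > 64 ug/mL

All three compounds share one core and differ only in the substituent on an amine nitrogen in a ring. In this assay compound 1 gives > 64 ug/mL, which is a limit of the assay and not a number. In the same test compound 2 gives > 64 ug/mL, again a limit. Compound 3 likewise gives > 64 ug/mL, also a limit. The three steps among them, a step that the two limits leave unreadable from compound 1 to compound 2, a step that the two limits leave unreadable from compound 1 to compound 3 and a step that the two limits leave unreadable from compound 2 to compound 3, are therefore not readable in size or direction. Where compound 3 stands is thus known only as a limit, and the same holds for the other two values; the one firm point is the limit of > 64 ug/mL in this assay, at which 3 of the 3 values shown sit.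

Compound 4 `CC(C)(C)c1ccc(CNN2CCN(c3nc(=O)c4cc(C(F)(F)F)cc([N+](=O)[O-])c4s3)CC2)cc1` is the next member. Relative to compound 3 the change is tert-butyl in place of trifluoromethyl on an aromatic carbon. Among the measured compounds shown here, no measured step bears readably on this exchange, since every neighbouring step is hidden behind the limit. Because the limit of > 64 ug/mL in this assay, at which 3 of the 3 values shown sit, holds for every value seen, compound 4 is expected to sit at that limit too, so the expected step of a number no higher from compound 3 to compound 4 (the limit leaves the size open) is none beyond the scatter. Compound 4 is estimated at 64 ug/mL, within a range from 32 ug/mL to 128 ug/mL.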

Compound 4, half-maximal cytotoxic concentration: > 64 ug/mL
Compound 4 was reported as a limit (the forecaster's own chance of this, stated with the estimate: 85%); the middle value lies on the limit itself.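

In this assay compound 4 gives > 64 ug/mL, a limit of the assay, so no new step can be read between it and compound 1, compound 2 or compound 3. The compounds shown leave open whether any substituent change, including tert-butyl in place of trifluoromethyl, alters this read-out, since all values share one limit: the limit of > 64 ug/mL in this assay, at which 4 of the 4 values shown sit.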